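Aryl variation on the five-membered ring in A549 proliferation

A few compounds are considered here, and "the series" means these few. Any claim that something is new, unique, unknown or untested is made for them only; others in the source may bear on it.

Compound 1 `Clc1ccc(C2CC(c3ccc(N4CCCCC4)cc3)=NN2c2nc(-c3ccccc3)cs2)cc1`, compound 2 `Clc1ccc(C2CC(c3ccc(N4CCCCC4)cc3)=NN2c2nc(-c3ccc(Br)cc3)cs2)cc1` and compound 3 `FC(F)(F)c1ccc(-c2csc(N3N=C(c4ccc(N5CCCCC5)cc4)CC3c3ccc(Cl)cc3)n2)cc1` share one core and differ only in the aryl group carried on the five-membered aromatic ring with one nitrogen and one sulfur. In a functional assay on A549 cells (Homo sapiens) for antiproliferative activity, read by MTT assay, with a stated time of 72 h (a lower number here means a stronger inhibitor, a higher number a weaker inhibitor), compound 1 gives 64200 nM, compound 2 gives 39700 nM and compound 3 gives 42000 nM, so compound 3 holds the second highest of the three numbers and lies within the scatter of both others. Compound 4 `Clc1ccc(C2CC(c3ccc(N4CCCCC4)cc3)=NN2c2nc(-c3ccc4ccccc4c3)cs2)cc1` is reached by naphthalen-2-yl in place of 4-(trifluoromethyl)phenyl on an aromatic carbon. Within the data shown here, the steps that bear on this are a 1.6-fold lower number from compound 1 to compound 2 (0.21 log units; within the scatter), a 1.5-fold lower number from compound 1 to compound 3 (0.18 log units; within the scatter) and a 1.1-fold higher number from compound 2 to compound 3 (0.02 log units; within the scatter), none beyond the scatter. The exchange for compound 4 is therefore expected to give no change at the digits printed from compound 3 to compound 4 (within the scatter), no shift beyond the scatter. Compound 4 is estimated at 42000 nM, within 20000 nM to 90000 nM.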

Compound 4, half-maximal inhibitory concentration: > 100000 nM
Compound 4: only a limit was reported (the forecaster's own chance of this, stated with the estimate: 15%); at least 2.3-fold (0.37 log units) between middle value and limit.
By their numbers in this assay, from the lowest: compounds 2, 3 and 1 (each within the scatter of the next). At a limit, above all of these: compound 4.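

In this assay compound 4 carries only a limit, > 100000 nM, so each step to it is a floor. Naphthalen-2-yl at this position gives an at least 2.3-fold higher number from compound 3 to compound 4 (0.37 log units; beyond the scatter) and an at least 2.5-fold higher number from compound 2 to compound 4 (0.40 log units; beyond the scatter), unlike the steps among compound 1, compound 2 and compound 3, none of which passes the scatter. The third step, an at least 1.5-fold higher number from compound 1 to compound 4 (0.19 log units; that floor lies within the scatter), cannot be read as a change.

On these data alone, how far compound 4 lies past its limit stays open. So does the effect of an amine or a carboxylic acid on the aryl group here.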